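The compounds below may be only part of what the source reports. "The series", "measured", "known", "first", "only" and "open" are said of these compounds alone.

Measured in an ADME assay on microsomes from liver (Mus musculus) for metabolic stability, read by LC-MS, using NADPH, with stated times of 6 min and 10 min, tested at 0.5 uM; on this read-out higher numbers stand for a more stable compound and lower numbers for a less stable compound:
Compound 1 `CC(=O)N1CCN(c2cc(-c3cc(Cl)c4c(N)ncnn34)ccc2C(F)(F)F)C(=O)C1(C)C` gives 88%
Compound 2 `COc1ccc(-c2cc(Cl)c3c(N)ncnn23)cc1N1CCN(C(C)=O)C(C)(C)C1=O` gives 94%
Compound 3 `CC(=O)N1CCN(c2cc(-c3cc(Cl)c4c(N)ncnn34)ccc2Cl)C(=O)C1(C)C` gives 67%

Compound 3 at 67% stands lowest of the three, and its gaps to both others lie beyond the scatter. Compound 4 `CC(=O)N1CCN(c2cc(-c3cc(Cl)c4c(N)ncnn34)ccc2S(C)(=O)=O)C(=O)C1(C)C` has not yet been measured. It differs from compound 3 by methylsulfonyl in place of chloro on an aromatic carbon, counted as methylsulfonyl in place of chloro on an aromatic carbon and placed ortho to a large group and para to a large group. Two measured steps at the same place bear on this change. Chloro in place of trifluoromethyl gave a number 21 percentage points lower from compound 1 to compound 3 (beyond the scatter) and chloro in place of methoxy gave a number 27 percentage points lower from compound 2 to compound 3 (beyond the scatter) with both steps modest in size. Methoxy in place of trifluoromethyl gave a number 6 percentage points higher from compound 1 to compound 2 (within the scatter) and so sets no order between those two groups. Among the measured compounds shown here, no compound carrying methylsulfonyl has been measured, so the expectation rests on analogy alone: a modest rise on leaving chloro. The expected change is a number 17 percentage points higher from compound 3 to compound 4 (beyond the scatter) and it would be modest. In this assay the estimated value for compound 4 is 84% within an expected range of 68% to 97%.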

Compound 4, percent of the compound remaining: 84%
Compound 4: middle estimate and measured number agree at the digits printed; low and high end bracket the measured number.
By their numbers in this assay, from the lowest: compound 3; then compounds 4, 1 and 2 (each within the scatter of the next).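

In this assay methylsulfonyl in place of chloro gives a number 17 percentage points higher from compound 3 to compound 4 (beyond the scatter) at this position, so a group entering with two hydrogen-bond acceptors stands clear of chloro. Against the other two groups it does not separate, since methylsulfonyl in place of methoxy gives a number 10 percentage points lower from compound 2 to compound 4 (within the scatter) and methylsulfonyl in place of trifluoromethyl gives a number 4 percentage points lower from compound 1 to compound 4 (within the scatter) in the same read-out. Among the compounds shown here, on this ring position, ortho to a large group and para to a large group, chloro in compound 3 is thus the only group of the four that stands apart, while compound 1, compound 2 and compound 4 cannot be told apart from one another.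

On these data alone, whether an amine, a carboxylic acid or an ethylsulfonyl group here would stay with those three or fall toward compound 3 remains open. Nothing available explains why chloro stands apart.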